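The source may report more compounds than this note shows. Statements on the series, on what has been measured and on what is new or still open speak of the compounds shown alone.

Measured compounds, values in a functional assay on A549 cells (Homo sapiens) for cytotoxicity, read by MTT assay, with a stated time of 72 h; a higher number here means a weaker inhibitor, a lower number a stronger inhibitor:
compound 1 `COc1cc2c(Oc3ccc(NC(=O)c4nnn(-c5ccccc5C)c4C)cc3F)ccnc2cc1OCCCN1CCCC1` — 380 nM
compound 2 `COc1cc2c(Oc3ccc(NC(=O)c4nnn(-c5ccccc5)c4C)cc3F)ccnc2cc1OCCCN1CCCC1` — 90 nM

Among the measured compounds shown here, compound 2 stands at the lower of the two numbers; the only step measured so far is a 4.2-fold lower number from compound 1 to compound 2 (0.63 log units; beyond the scatter), which removed a methyl from the phenyl ring. Compound 3 `COc1cc2c(Oc3ccc(NC(=O)c4nnn(-c5ccccc5C(F)(F)F)c4C)cc3F)ccnc2cc1OCCCN1CCCC1` differs from compound 2 by trifluoromethyl in place of hydrogen on an aromatic carbon. For the measured compounds named here, the single step that bears on this, a 4.2-fold lower number from compound 1 to compound 2 (0.63 log units; beyond the scatter), shows that a substituent at this place raises the number, and a trifluoromethyl is a larger group than methyl, so a comparable or somewhat larger rise is expected: a 5.0-fold higher number from compound 2 to compound 3 (0.70 log units; beyond the scatter) is the expected step. Compound 3 is therefore estimated at 450 nM, with a range of 130 nM to 1600 nM.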

Compound 3, half-maximal inhibitory concentration: 160 nM
Compound 3: the middle estimate sits 2.8-fold (0.45 log units) above what was measured; measured number inside the range.
By their numbers in this assay, from the lowest: compounds 2 and 3 (each within the scatter of the next); then compound 1.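

In this assay, a substituent at this place does not always raise the number: with a 1.8-fold higher number from compound 2 to compound 3 (0.25 log units; within the scatter), trifluoromethyl stands level with hydrogen. The rise seen with methyl therefore does not hold for every group here, and compound 1 is the compound that goes against a free tolerance of substitution, with a 2.4-fold lower number from compound 1 to compound 3 (0.38 log units; beyond the scatter). No measurement explains the difference between the two groups.

Open, as far as these compounds go, is what an amine, a methoxy or a chlorine gives at this place. Also open, from the compounds shown here alone, is how trifluoromethyl behaves on the other carbons of this ring.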